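From bromo to furan-2-yl on compound 3

A few compounds are considered here, and "the series" means these few. Any claim that something is new, unique, unknown or untested is made for them only; others in the source may bear on it.

In a functional assay on L1210 cells (Mus musculus) for antiproliferative activity, read by cell counting, with a stated time of 48 h (on this read-out higher numbers stand for weaker inhibition and lower numbers for stronger inhibition), compound 1 `C#C[C@@]1(O)[C@@H](CO)O[C@@H](n2cnc3c(-c4ccccc4)ncnc32)[C@@H]1O` gives > 250000 nM, which is a limit and not a number. Compound 2 `C#C[C@@]1(O)[C@@H](CO)O[C@@H](n2cnc3c(-c4ccc(F)cc4)ncnc32)[C@@H]1O` gives > 250000 nM, again a limit. Going by the values given here, compound 3 `C#C[C@@]1(O)[C@@H](CO)O[C@@H](n2cc(Br)c3c(N)ncnc32)[C@@H]1O` gives 28 nM, the only true number among the three. Compound 4 `C#C[C@@]1(O)[C@@H](CO)O[C@@H](n2cc(-c3ccco3)c3c(N)ncnc32)[C@@H]1O` is still unmeasured and differs from compound 3 in one place: furan-2-yl in place of bromo on an aromatic carbon. Among the compounds with values here, the single measured step, a step that the two limits leave unreadable from compound 1 to compound 2, concerns fluoro in place of hydrogen and has no readable size, so it offers no guide. That leaves compound 3 at 28 nM as the only anchor, and some weakening in this assay is expected, with wide uncertainty. The expected change is a 21-fold higher number from compound 3 to compound 4 (1.33 log units; beyond the scatter). For compound 4 the estimate is 600 nM, with an expected range from 40 nM to 20000 nM.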

Compound 4, half-maximal inhibitory concentration: 30000 nM
Compound 4: middle estimate off by 50-fold (1.70 log units), on the low side, and the stated range ends below it.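

In this assay, going by these compounds alone, furan-2-yl in place of bromo gives a 1100-fold higher number from compound 3 to compound 4 (3.03 log units; beyond the scatter), the first change on this core whose size can be read. This aromatic carbon therefore does not accept every group, and one swap there removes most of the inhibition. Even so, compound 4 keeps a true number and does not reach the limit, which is not a number: the limit of > 250000 nM in this assay, at which 2 of the 4 values shown sit.

On these data alone, with only bromo and furan-2-yl at this carbon, it remains open whether the loss goes with the added ring or with the furan oxygen. A methyl, a chloro or a thiophen-2-yl at the same place would help separate these possibilities.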